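Cyclopropyl for methoxybenzoyl on the amine of compound 3

The source may hold more compounds than are shown below. What is called first, only, known or untested is meant among the compounds shown, and "the series" means these compounds.

Three compounds have been measured:
compound 1, `Clc1ccccc1Cn1nnc2c(NC3CCCCC3)nc(-c3ccccc3)nc21`, 34000000 nM;
compound 2, `CCNc1nc(-c2ccccc2)nc2c1nnn2Cc1ccccc1Cl`, 463000000 nM;
compound 3, `COc1ccc(C(=O)Nc2nc(-c3ccccc3)nc3c2nnn3Cc2ccccc2Cl)cc1`, 20000000 nM.

In an assay on isolated protein for binding affinity to adenosine receptor A1 (Bos taurus) (on this read-out higher numbers stand for weaker inhibition and lower numbers for stronger inhibition), compound 3 gives the lowest of the three numbers. Compound 1 is nearest to it, and that gap, a 1.7-fold lower number from compound 1 to compound 3 (0.23 log units; within the scatter), is within the scatter. Compound 2 is furthest away: a 23-fold lower number from compound 2 to compound 3 (1.36 log units; beyond the scatter) is a large step beyond the scatter.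

Compound 4, `Clc1ccccc1Cn1nnc2c(NC3CC3)nc(-c3ccccc3)nc21`, differs from compound 3 in one place: cyclopropyl in place of (4-methoxyphenyl)carbonyl on a nitrogen on an aromatic ring. The three compounds already measured all vary at this same nitrogen. Among the measured compounds shown here, two measured steps bear on the change. The first, a 14-fold higher number from compound 1 to compound 2 (1.13 log units; beyond the scatter), shows that a small ethyl on this nitrogen gives a much higher number than cyclohexyl. The second, a 23-fold lower number from compound 2 to compound 3 (1.36 log units; beyond the scatter), shows that the methoxyphenylcarbonyl group sits far below ethyl. Cyclopropyl is a small ring with no hydrogen-bond acceptors, and it stands in size between ethyl and cyclohexyl. A higher number than compound 3 is therefore expected, with the step of a 5.0-fold higher number from compound 3 to compound 4 (0.70 log units; beyond the scatter) landing somewhere between the ethyl and cyclohexyl outcomes. For compound 4 the estimate in this assay is 100000000 nM, with a range from 25000000 nM to 500000000 nM.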

Compound 4, inhibition constant: 11000000 nM
Beside the measured number, compound 4's estimate is 9.1-fold (0.96 log units) above it; the whole stated range lies above it.
By their numbers in this assay, from the lowest: compounds 4, 3 and 1 (each within the scatter of the next, the first and the last beyond it); then compound 2.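

In this assay, with a 1.8-fold lower number from compound 3 to compound 4 (0.26 log units; within the scatter), cyclopropyl and (4-methoxyphenyl)carbonyl cannot be told apart on this nitrogen, although one has 3 heavy atoms and no hydrogen-bond acceptors and the other has 10 heavy atoms and 2 hydrogen-bond acceptors. The swap from ethyl to cyclopropyl, two small carbon-only groups, gives the large change a 42-fold lower number from compound 2 to compound 4 (1.62 log units; beyond the scatter), so small size alone does not go with a high number at this position. The modest step of a 3.1-fold lower number from compound 1 to compound 4 (0.49 log units; beyond the scatter) then shows that among the three carbon-only groups the number does not follow size: ethyl in compound 2 gives the highest number, cyclohexyl in compound 1 a middle one and cyclopropyl in compound 4 the lowest.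

The compounds shown leave open whether a cyclobutyl ring or a propyl chain on this nitrogen would read like cyclopropyl or like ethyl. Nothing available here explains why ethyl and cyclopropyl stand so far apart.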